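Swapping a Para Substituent on the Amide Ring

This account rests on a few compounds, and the source may have more. Where it says the series, first, only, none or still open, it means among the compounds named here.

Of the compounds shown here, two of the same core have been measured. Compound 1 `O=C(Nc1cccc(-c2oc3cc(-c4ccc(F)cc4)ccc3c(=O)c2O)c1)c1ccc(F)cc1F` gives 13500 nM in a functional assay on MCF7 cells (Homo sapiens) for antiproliferative activity, read by CCK-8 assay, with a stated time of 72 h; a lower number here means a stronger inhibitor, a higher number a weaker inhibitor. For the measured compounds named here, compound 2 `O=C(Nc1cccc(-c2oc3cc(-c4ccc(F)cc4)ccc3c(=O)c2O)c1)c1ccc(C(F)(F)F)cc1` gives 32600 nM in this assay and thus stands at the higher, weaker end of the two numbers, with compound 1 as its only neighbour. Going by the values given here, the one measured step, a 2.4-fold higher number from compound 1 to compound 2 (0.38 log units; beyond the scatter), shows that changing the substitution on the ring attached to the carbonyl moves the number modestly.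

Compound 3 `O=C(Nc1cccc(-c2oc3cc(-c4ccc(F)cc4)ccc3c(=O)c2O)c1)c1ccc(Br)cc1` differs from compound 2 by bromo in place of trifluoromethyl on an aromatic carbon. Among the compounds with values here, no measured step changes only this one group, so the measured step from compound 1 to compound 2 bears on it only loosely: it shows that such ring substituents shift the number by a modest amount rather than by a large one. Compound 3 is therefore expected to stay close to compound 2, with a step of a 1.3-fold lower number from compound 2 to compound 3 (0.12 log units; within the scatter) in this assay, within or barely beyond the scatter and in no confidently predicted direction. The estimate for compound 3 is 25000 nM, with a range from 10000 nM to 60000 nM.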

Compound 3, half-maximal inhibitory concentration: 24000 nM
Beside the measured number, compound 3's estimate is 1.0-fold (0.02 log units) above it; low and high end bracket the measured number.
By their numbers in this assay, from the lowest: compounds 1, 3 and 2 (each within the scatter of the next, the first and the last beyond it).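

Bromo in place of trifluoromethyl at this spot, para to a large group, gives a 1.4-fold lower number from compound 2 to compound 3 (0.13 log units; within the scatter) in this assay, so a single bromine and the four heavy atoms of trifluoromethyl cannot be told apart in this read-out. The 4-bromophenyl group in place of 2,4-difluorophenyl gives a 1.8-fold higher number from compound 1 to compound 3 (0.25 log units; within the scatter), so compound 3 lies within the scatter of both other compounds, even though those two differ by more than the scatter, and the three do not fall into clearly separated levels. No measurement is at hand that could explain these numbers.

As far as these compounds go, all three compounds keep the shared core and carry only fluoro, bromo or trifluoromethyl on the ring attached to the carbonyl, so it remains open whether an amine, a carboxylic acid or a methoxy group on this ring would move the number by more than these small steps. From the compounds shown here alone, it also remains open whether a change elsewhere on the shared core, rather than on this ring, would shift the number further.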